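The compounds below may be only part of what the source reports. "The series", "measured", "known", "first", "only" and "open" are said of these compounds alone.

Measured in a functional assay on SK-BR-3 cells (Homo sapiens) for cytotoxicity, read by CellTiter-Glo, with a stated time of 72 h; a higher number here means a weaker inhibitor, a lower number a stronger inhibitor:
- compound 1 `C=CCO/N=C1/[C@@H](OC)C[C@H](C)CC2=C(NCCN(C)C)C(=O)C=C(NC(=O)/C(C)=C/C=C\[C@H](OC)[C@@H](OC(N)=O)/C(C)=C/[C@@H]1C)C2=O`: 400 nM
- compound 2 `CO/N=C1/[C@@H](OC)C[C@H](C)CC2=C(NCCN(C)C)C(=O)C=C(NC(=O)/C(C)=C/C=C\[C@H](OC)[C@@H](OC(N)=O)/C(C)=C/[C@@H]1C)C2=O`: 550 nM

Among the compounds with values here, compound 2, at 550 nM, stands level with compound 1, since the only measured step is a 1.4-fold higher number from compound 1 to compound 2 (0.14 log units; within the scatter). That step swapped vinyl for hydrogen on a saturated chain carbon bound to an oxygen.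

Compound 3 `CO[C@H]1C[C@H](C)CC2=C(NCCN(C)C)C(=O)C=C(NC(=O)/C(C)=C/C=C\[C@H](OC)[C@@H](OC(N)=O)/C(C)=C/[C@H](C)/C1=N\OCC(=O)O)C2=O` differs from compound 2 at that same carbon: carboxy in place of hydrogen on a saturated chain carbon bound to an oxygen. In words, this is carboxy in place of hydrogen, turning methoxy into carboxymethoxy. Within the data shown here, no measured compound carries a carboxy, so the small measured step is only a weak guide here. A move towards a higher number in this assay is a judgement, not something the data show. The expected step is a 2.7-fold higher number from compound 2 to compound 3 (0.44 log units; beyond the scatter), which would lie beyond the scatter. Compound 3 is estimated at 1500 nM, with an expected range of 400 nM to 6000 nM.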

Compound 3, half-maximal inhibitory concentration: 2700 nM
Compound 3: middle estimate off by 1.8-fold (0.26 log units), on the low side; low and high end bracket the measured number.
By their numbers in this assay, from the lowest: compounds 1 and 2 (each within the scatter of the next); then compound 3.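

In this assay the earlier change at this saturated chain carbon bound to an oxygen stayed within the scatter, so the position could have seemed indifferent to what sits there, but the carboxy group moves the number beyond the scatter. Turning methoxy into carboxymethoxy gives a 4.9-fold higher number from compound 2 to compound 3 (0.69 log units; beyond the scatter) and putting carboxy in place of vinyl gives a 6.8-fold higher number from compound 1 to compound 3 (0.83 log units; beyond the scatter) so, among these three compounds, the carboxy-bearing one stands apart from the other two at a higher number, which means a weaker inhibitor. Nothing measured here explains this rise.

The compounds shown leave open whether the higher number belongs to the free carboxylic acid itself, since a methyl ester or an amine at the same place would separate that from the added atoms. A longer chain carrying the carboxy group is equally untested in what is shown here.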